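The compounds below may be only part of what the source reports. "The series", "measured", "known", "first", "only" and "open" are said of these compounds alone.

In an ADME assay on LLC-MK2 cells (Macaca mulatta) for cytotoxicity, read by spectrophotometry and crystal violet staining, with a stated time of 4 days (a lower number here means that less compound is tolerated, a higher number that more compound is tolerated), compound 1 (`CC(C)n1ncc2c(C(=O)Nc3ccc(F)c(F)c3)cc(-c3cccs3)nc21`) gives > 200000 nM, a limit and not a number. Compound 2 (`CC(C)n1ncc2c(C(=O)Nc3c(F)cc(F)cc3F)cc(-c3cccs3)nc21`) gives > 200000 nM, also a limit, so its position in the series is only bounded. All the evidence so far is the limit of > 200000 nM in this assay, at which 2 of the 2 values shown sit. Compound 3 (`CC(C)n1ncc2c(C(=O)Nc3ccccc3S(N)(=O)=O)cc(-c3cccs3)nc21`) carries 2-sulfamoylphenyl in place of 2,4,6-trifluorophenyl on an amide-type nitrogen. Among the measured compounds shown here, the one measured step, a step that the two limits leave unreadable from compound 1 to compound 2, gives no size to carry over, so no change beyond the scatter is expected, and a further limit is the likeliest reading. The expected step is an at least 1.1-fold lower number from compound 2 to compound 3 (0.07 log units; that floor lies within the scatter). For compound 3 the estimate is 170000 nM, with an expected range of 80000 nM to 200000 nM.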

Compound 3, half-maximal cytotoxic concentration: 25000 nM
For compound 3 the middle estimate is 6.8-fold (0.83 log units) above the measured one, outside the stated range (below it).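

In this assay, this amide-nitrogen position is the first shown to shift the read-out, with the change to 2-sulfamoylphenyl giving an at least 8.0-fold lower number from compound 2 to compound 3 (0.90 log units; beyond the scatter). Against the 3,4-difluorophenyl amide the same group gives an at least 8.0-fold lower number from compound 1 to compound 3 (0.90 log units; beyond the scatter). Both steps are floors and not sizes, since compound 1 and compound 2 are known only as limits: the limit of > 200000 nM in this assay, at which 2 of the 3 values shown sit.

As far as these compounds go, whether the lower number follows the sulfamoyl group specifically remains open. A phenyl carrying a carboxylic acid or an amine on the same amide nitrogen would show whether other groups there also lower it.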